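A Methoxy Group Added to the Open-Chain Compound 3

The compounds below may be only part of what the source reports. "The series", "measured", "known", "first", "only" and "open" are said of these compounds alone.

Measured compounds:
compound 1, `COc1cc2occ(-c3csc4ccccc34)c(=O)c2cc1OC`: > 10000 nM
compound 2, `COc1cc2c(=O)c(-c3csc4ccccc34)coc2c(OC)c1OC`: > 10000 nM
compound 3, `O=C(/C=C/c1csc2ccccc12)c1ccccc1O`: 6200 nM

All values come from a functional assay on KB cells (Homo sapiens) for antiproliferative activity, read by sulforhodamine B assay, with a stated time of 72 h; on this read-out lower numbers stand for stronger inhibition and higher numbers for weaker inhibition. For compound 1 the value > 10000 nM is a limit of the assay, not a number. For compound 2 the value > 10000 nM is likewise a limit. Compound 2 differs from compound 1 by methoxy in place of hydrogen on an aromatic carbon, and the step that the two limits leave unreadable from compound 1 to compound 2 cannot be sized because of the limit of > 10000 nM in this assay, at which 2 of the 3 values shown sit. Among the measured compounds shown here, compound 3 is the only one with a real number, 6200 nM in this assay; how its core differs from the core of compound 1 is not broken down here.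

Compound 4, `COc1ccc(C(=O)/C=C/c2csc3ccccc23)c(O)c1`, has not yet been measured. It differs from compound 3 by methoxy in place of hydrogen on an aromatic carbon. For the measured compounds named here, this is the same kind of change as the one from compound 1 to compound 2, but the surroundings differ: in compound 2 the methoxy sits on a ring that is part of a fused system, ortho to a fused ring and to a methoxy group, whereas in compound 4 it sits meta to a hydroxy group and para to a large group. The earlier step gives no readable size, so the expectation rests on compound 3 alone. Resting on compound 3 and its value 6200 nM, compound 4 is expected to give about 5000 nM, between 1500 nM and 15000 nM. This corresponds to an expected step of a 1.2-fold lower number from compound 3 to compound 4 (0.09 log units; within the scatter).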

Compound 4, half-maximal inhibitory concentration: 5600 nM
Beside the measured number, compound 4's estimate is 1.1-fold (0.05 log units) below it; low and high end bracket the measured number.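

In this assay, putting methoxy in place of hydrogen on an aromatic carbon of the open-chain compound gives a 1.1-fold lower number from compound 3 to compound 4 (0.04 log units; within the scatter), so on this core the change makes no difference that can be told apart from the ordinary spread of repeated measurements. The same change from compound 1 to compound 2 cannot be read, because each of these two compounds gives a limit of the assay rather than a number: the limit of > 10000 nM in this assay, at which 2 of the 4 values shown sit. This leaves a single readable case, which describes only the core of compound 3 and shows neither that the change behaves alike on the core of compound 1 nor that it behaves differently there.

The compounds shown leave open whether methoxy would matter more on another aromatic carbon of compound 3. They also leave open whether a different group on that same carbon, such as an amine, a carboxylic acid or a longer chain, would move the number beyond the scatter.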